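The compounds below may be only part of what the source reports. "The series", "measured", "known", "first", "only" and "open" are said of these compounds alone.

Measured so far:
compound 1, `Cc1cccc(-c2nc(CNc3ccc(C(=O)NO)cc3)n(-c3ccccc3)n2)c1`: 281 nM
compound 2, `O=C(NO)c1ccc(NCc2nc(-c3cccs3)nn2-c2ccc(O)cc2)cc1`: 33.5 nM

In an assay on Sf9 cells for inhibition of protein deacetylase HDAC6 (Homo sapiens), read by fluorescence, with a stated time of 40 min (on this read-out lower numbers stand for stronger inhibition and higher numbers for weaker inhibition), compound 1 gives 281 nM, the higher of the two numbers. Compound 2 gives 33.5 nM, and the gap to compound 1 lies beyond the scatter. Compound 3, `COc1ccc(-c2nc(CNc3ccc(C(=O)NO)cc3)n(-c3ccccc3)n2)cc1`, differs from compound 1 in one place: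

4-methoxyphenyl in place of 3-methylphenyl on an aromatic carbon

Among the compounds with values here, no measured pair shows this change, so its size is open. A step within the scatter, with no clear direction, is expected in this assay. For compound 3 the estimate is 220 nM, with a range from 80 nM to 600 nM. This expected value corresponds to a step of a 1.3-fold lower number from compound 1 to compound 3 (0.11 log units; within the scatter).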

Compound 3, half-maximal inhibitory concentration: 163 nM
Compound 3: middle estimate off by 1.3-fold (0.13 log units), on the high side; the range from low to high includes it.
By their numbers in this assay, from the lowest: compound 2; then compounds 3 and 1 (each within the scatter of the next).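

Within the data shown here, replacing 3-methylphenyl with 4-methoxyphenyl on this aromatic carbon gives a 1.7-fold lower number from compound 1 to compound 3 (0.24 log units; within the scatter) and is the first step read at this position. Across this pair, the position accepts either substituted phenyl group, and the hydrogen-bond acceptor that enters with 4-methoxyphenyl brings no change beyond the scatter. Nothing at hand explains this result.

On these data alone, whether an amine, a carboxylic acid or a longer alkyl chain on this carbon would keep the number in this range remains open. A single pair also leaves open how the 4-methoxyphenyl group behaves with other groups on the shared core.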